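Straight Against Branched Chain on a Shared Core

The source may report more compounds than this note shows. Statements on the series, on what has been measured and on what is new or still open speak of the compounds shown alone.

Three compounds share one core and differ in the group carried on one aromatic carbon. Compound 1 `Cn1ncc2c(-c3ccccc3)cc(NNC(=O)Nc3cc(Cl)nc(Cl)c3)nc21` bears a phenyl there; in an assay on isolated protein for binding affinity to sphingosine 1-phosphate receptor 2 (Homo sapiens), read by surface plasmon resonance (on this read-out higher numbers stand for weaker binding and lower numbers for tighter binding), compound 1 gives 1020 nM. Compound 2 `CC(C)c1cc(NNC(=O)Nc2cc(Cl)nc(Cl)c2)nc2c1c(C(F)(F)F)nn2C` gives 1250 nM in this assay. Compound 3 `CCCc1cc(NNC(=O)Nc2cc(Cl)nc(Cl)c2)nc2c1cnn2C` gives 1400 nM in this assay, the highest of the three numbers, though each of its gaps to the others lies within the scatter, and a 1.4-fold higher number from compound 1 to compound 3 (0.14 log units; within the scatter). Compound 4 `CC(C)c1cc(NNC(=O)Nc2cc(Cl)nc(Cl)c2)nc2c1cnn2C` differs from compound 3 by isopropyl in place of propyl on an aromatic carbon. Going by the values given here, no measured step exchanges one alkyl chain for another of the same size; the only step touching this position, a 1.4-fold higher number from compound 1 to compound 3 (0.14 log units; within the scatter), was itself within the scatter. No step beyond the scatter is therefore expected, no change at the digits printed from compound 3 to compound 4 (within the scatter). Compound 4 is estimated at 1400 nM in this assay, with a range from 700 nM to 2800 nM.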

Compound 4, dissociation constant: 780 nM
The estimate for compound 4 lay 1.8-fold (0.25 log units) above the measured number; the range from low to high includes it.
By their numbers in this assay, from the lowest: compounds 4, 1, 2 and 3 (each within the scatter of the next).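

Isopropyl in place of propyl, the same three carbons joined differently, gives a 1.8-fold lower number from compound 3 to compound 4 (0.25 log units; within the scatter) in this assay, so at this position the shape of the chain has not moved binding beyond the scatter, and neither has isopropyl in place of phenyl, a 1.3-fold lower number from compound 1 to compound 4 (0.12 log units; within the scatter). Hydrogen in place of trifluoromethyl on an aromatic carbon gives a 1.6-fold lower number from compound 2 to compound 4 (0.20 log units; within the scatter), which is also no clear change. Nothing measured here accounts for these small differences. As far as these compounds go, whether an amine, a carboxylic acid or a longer chain at this position would shift binding beyond the scatter remains open.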